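This account rests on a few compounds, and the source may have more. Where it says the series, first, only, none or still open, it means among the compounds named here.

Three compounds have been measured in an ADME assay on HBZY-1 cells (Rattus norvegicus) for cytotoxicity, read by MTT assay, with a stated time of 2 h; on this read-out higher numbers stand for weaker inhibition and lower numbers for stronger inhibition:

Compound 1 `COc1cc(NC(=O)/C=C/c2ccccc2C(F)(F)F)cc(OC)c1OC`: > 200000 nM (a limit of the assay)
Compound 2 `COc1ccc(NC(=O)/C(C#N)=C/c2ccccc2C(F)(F)F)cc1OC`: > 200000 nM (a limit of the assay)
Compound 3 `COc1ccccc1NC(=O)/C(C#N)=C/c1cccc([N+](=O)[O-])c1`: > 200000 nM (a limit of the assay)

Among the measured compounds shown here, none of these entries is a true number, and the series so far is described by the limit of > 200000 nM in this assay, at which 3 of the 3 values shown sit. Compound 3 therefore has no position of its own in the series. In this assay compound 3 reads > 200000 nM, which is a limit and not a number.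

Compound 4 `COc1ccccc1NC(=O)/C(C#N)=C/c1cccc(C)c1` differs from compound 3 at a single place. It has methyl in place of nitro on an aromatic carbon, meta to a large group (methyl in place of nitro on an aromatic carbon).

For the measured compounds named here, no pair of measured compounds differs in one place only, so the data offer no measured step for this change. The expectation therefore rests on compound 3 and its limit of > 200000 nM. No step beyond the usual scatter is expected in this assay, and compound 4 is expected to be reported as a limit as well. The expected size of the change is a number no higher from compound 3 to compound 4 (the limit leaves the size open). For compound 4 the estimate is 200000 nM, with an expected range from 100000 nM to 400000 nM.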

Compound 4, half-maximal inhibitory concentration: > 200000 nM
Compound 4: a limit, no number; the forecaster's own chance of this, stated with the estimate: 85%; the middle value lies on the limit itself.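

In this assay compound 4 gives > 200000 nM, which is a limit of the assay and not a number. Compound 3 is also reported only as a limit, so no step can be read between compound 3 and compound 4. The compounds shown leave open what true number any of them would give in this assay, as the whole series rests on one limit: the limit of > 200000 nM in this assay, at which 4 of the 4 values shown sit.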